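This account rests on a few compounds, and the source may have more. Where it says the series, first, only, none or still open, it means among the compounds named here.

Compound 1, `Fc1cccc(N2CCN(CCCOc3ccc4c(c3)CCC4)CC2)c1`: 42%
Compound 2, `COc1ccc(N2CCN(CCCOc3ccc4c(c3)CCC4)CC2)cc1`: 37%

In a functional assay on the whole organism for inhibition, with Mus musculus as the target, at a dose of 25 mg/kg by the oral route (a higher number here means more inhibition at the dose given (going by the name of the read-out), a lower number less inhibition), compound 2 gives 37%, the lower of the two numbers, with compound 1 nearest at 42%; the two lie within the scatter of each other. Compound 3, `O=[N+]([O-])c1ccc(N2CCN(CCCOc3ccc4c(c3)CCC4)CC2)cc1`, differs from compound 2 in one place: nitro in place of methoxy on an aromatic carbon. Among the measured compounds shown here, only one measured step touches this position, a number 5 percentage points lower from compound 1 to compound 2 (within the scatter), and it did not leave the scatter. For the measured compounds named here, no step pairs nitro against methoxy, so nothing points to a change beyond the scatter, and the step from compound 2 is estimated as a number 1 percentage points higher from compound 2 to compound 3 (within the scatter). Compound 3 is therefore expected to give about 38%, within a range of 20% to 56%.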

Compound 3, a percentage reported as inhibition, in the whole organism at one dose (the size of the read-out at that dose, not a potency): 26%
For compound 3 the middle estimate is 12 percentage points above the measured one, within the range that was stated.
By their numbers in this assay, from the lowest: compound 3; then compounds 2 and 1 (each within the scatter of the next).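

In this assay, among the compounds shown here, the aromatic carbon para to a large group responds to what it carries: nitro in place of methoxy gives a number 11 percentage points lower from compound 2 to compound 3 (beyond the scatter), the first step beyond the scatter. The change from 3-fluorophenyl to 4-nitrophenyl gives a number 16 percentage points lower from compound 1 to compound 3 (beyond the scatter), so compound 3 stands apart from both earlier compounds, which lie within the scatter of each other. Nothing available explains this step.

Going by these compounds, whether the step is specific to nitro or would recur with a nitrile or trifluoromethyl on the same carbon stays open. So does the effect of an amine or a carboxylic acid there.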